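The compounds below may be only part of what the source reports. "The series", "measured", "known", "first", "only" and "open" are said of these compounds alone.

Measured so far in an ADME assay on microsomes from liver (Mus musculus) for metabolic stability; a higher number here means faster removal of the compound, a lower number slower removal:
- compound 1, `COc1cc(OC)c(NC(=O)Cc2cn(C)c3ccccc23)cc1Cl`: 4050 mL/min/kg
- compound 2, `C[C@H](C(=O)O)n1nc(Cn2cc3cc(OCC4CC4)c(Cl)cc3n2)c2ccccc2c1=O`: < 66.7 mL/min/kg
- compound 3, `O=C(O)Cn1nc(Cc2cn3cc(OCC4CC4)c(Cl)cc3n2)c2ccccc2c1=O`: < 58.4 mL/min/kg

Among the compounds with values here, compound 1 gives a numerical clearance in this assay, 4050 mL/min/kg, and is the only compound of the three with a number rather than a limit. Compound 2 gives only a limit in this assay, < 66.7 mL/min/kg. Compound 3 likewise gives only a limit, < 58.4 mL/min/kg. Compound 2 therefore stands at the limit of < 66.7 mL/min/kg in this assay, at which 1 of the 3 values shown sits, with no number to compare against; compound 3 stands at the limit of < 58.4 mL/min/kg in this assay, at which 1 of the 3 values shown sits. Within the data shown here, no pair of measured compounds differs in a single place, so no measured step exists on which to base a size.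

Compound 4, `O=C(O)Cn1nc(Cn2cc3cc(OCC4CC4)c(Cl)cc3n2)c2ccccc2c1=O`, differs from compound 2 by hydrogen in place of methyl on a saturated chain carbon bound to an aromatic nitrogen and a carbonyl carbon. Compound 3 carries the carboxymethyl arm on a related core and sits at its limit, so the expectation is that the step from compound 2 to compound 4 is none beyond the scatter in this assay, with clearance remaining low; the estimated step is a step that the limit leaves unreadable from compound 2 to compound 4. Compound 4 is expected at 40 mL/min/kg, in the range 10 mL/min/kg to 90 mL/min/kg, most likely reported again only as a limit.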

Compound 4, clearance: < 85 mL/min/kg
Compound 4: only a limit was reported; the forecaster's own chance of this, stated with the estimate: 75%; the middle value lies beyond the limit too.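

Compound 2 and compound 4 are both reported only as limits in this assay, so no step can be read for the change from 1-carboxyethyl to carboxymethyl. The compounds shown leave open the numerical clearance of compound 2 and of compound 4, and whether hydrogen in place of methyl at this place alters clearance at all.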